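Adding a methyl to the acid chain of compound 2

The source may report more compounds than this note shows. Statements on the series, on what has been measured and on what is new or still open speak of the compounds shown alone.

compound 1 `O=C(O)Cn1nc(Cc2nc3cc(Cl)c(OCC(F)F)cc3[nH]2)c2ccccc2c1=O` limit < 28.4 mL/min/kg
compound 2 `O=C(O)Cn1nc(Cn2cc3cc(OCC4CC4)c(Cl)cc3n2)c2ccccc2c1=O` limit < 40 mL/min/kg
compound 3 `O=C(O)Cc1nn(Cc2cn3cc(OCC4CC4)c(Cl)cc3n2)c2ccccc2c1=O` value 30 mL/min/kg

In an ADME assay on cells (Hepatocyte, Mus musculus) for metabolic stability, read by LC-MS, with a stated time of 180 min, tested at 1 uM (on this read-out higher numbers stand for fast clearance and lower numbers for slow clearance), compound 2 is known only as a limit (< 40 mL/min/kg). Compound 1 also gives only a limit (< 28.4 mL/min/kg). For the measured compounds named here, compound 3 is the only one with a measured number (30 mL/min/kg).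

Compound 4 `C[C@H](C(=O)O)n1nc(Cn2cc3cc(OCC4CC4)c(Cl)cc3n2)c2ccccc2c1=O` differs from compound 2 by one change (methyl in place of hydrogen on a saturated chain carbon bound to an aromatic nitrogen and a carbonyl carbon), methyl in place of hydrogen on a saturated chain carbon bound to an aromatic nitrogen and a carbonyl carbon. The same difference reads carboxymethyl to 1-carboxyethyl. Going by the values given here, no measured pair shows this change. In this assay no step beyond the scatter is expected, in either direction. The expected step is small (a step that the limit leaves unreadable from compound 2 to compound 4). The estimate for compound 4 is 30 mL/min/kg with an expected range of (14 mL/min/kg to 60 mL/min/kg).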

Compound 4, clearance in the Hepatocyte assay: 63.3 mL/min/kg
For compound 4 the middle estimate is 2.1-fold (0.32 log units) below the measured one; measured number outside the range, above it.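

With methyl in place of hydrogen on the saturated chain carbon bound to an aromatic nitrogen and a carbonyl carbon, the Hepatocyte assay gives an at least 1.5-fold higher number from compound 2 to compound 4 (0.19 log units; that floor lies within the scatter). For the compounds shown here, this is the first reading of a change at this position, and as compound 2 stands only as a limit, the true size of the step stays unknown. In a physicochemical assay for solubility, measured as thermodynamic solubility, at pH 7.4 (a lower number here means a less soluble compound, a higher number a more soluble compound), compound 2 gives 334 ug/mL, and compound 4 gives 958 ug/mL. The same change also moves the physicochemical assay: the measured solubility of compound 2, 334 ug/mL, and of compound 4, 958 ug/mL, a 2.9-fold higher number (0.46 log units; beyond the scatter)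

The compounds shown leave open how the mirror-image 1-carboxyethyl group would read in either assay. They also leave open how an ethyl or a second methyl on that carbon would read.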